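Fluorine Moved, Methyl Removed: What to Expect for Compound 3

The source may hold more compounds than are shown below. What is called first, only, known or untested is meant among the compounds shown, and "the series" means these compounds.

In a functional assay on HL-60 cells (Homo sapiens) for activation, read by flow cytometry, with a stated time of 4 days (on this read-out lower numbers stand for an effect already at smaller amounts and higher numbers for an effect only at larger amounts of compound), compound 2 `COc1ccc(-n2cnc3cnc(-c4cc(F)ccc4C)cc32)cc1OC` gives 2500 nM, the highest of the two numbers seen so far. Compound 1 `COc1ccc(-n2cnc3cnc(-c4ccccc4C)cc32)cc1OC` gives 69 nM in this assay. For the measured compounds named here, the single measured step, a 36-fold higher number from compound 1 to compound 2 (1.56 log units; beyond the scatter), arises from fluoro in place of hydrogen on an aromatic carbon. Compound 3 `COc1ccc(-n2cnc3cnc(-c4ccc(F)cc4)cc32)cc1OC` differs from compound 2 by 4-fluorophenyl in place of 5-fluoro-2-methylphenyl on an aromatic carbon. Going by the values given here, the fluorine found in compound 2 departs with the methyl, and a fluorine enters elsewhere, a change that no measured step covers. Compound 3 is therefore expected to fall between the two measured values, a step of a 4.2-fold lower number from compound 2 to compound 3 (0.62 log units; beyond the scatter). The estimate for compound 3 is 600 nM, within a range from 100 nM to 4000 nM.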

Compound 3, half-maximal effective concentration: 780 nM
Compound 3: the middle estimate sits 1.3-fold (0.11 log units) below what was measured; low and high end bracket the measured number.
By their numbers in this assay, from the lowest: compound 1; then compound 3; then compound 2.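

For the compounds shown here, exchanging 5-fluoro-2-methylphenyl for 4-fluorophenyl at this position in this assay gives a 3.2-fold lower number from compound 2 to compound 3 (0.51 log units; beyond the scatter) and shows that a fluorine-bearing phenyl group here can read lower than the one in compound 2. Exchanging 2-methylphenyl for 4-fluorophenyl still gives an 11-fold higher number from compound 1 to compound 3 (1.05 log units; beyond the scatter) and leaves compound 1 with the lowest number of the three. No available evidence explains either step.

Without plain phenyl among these compounds, the separate contributions of the methyl and the fluorine remain open. From the compounds shown here alone, how an amine or a carboxylic acid on this ring would read also remains open.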